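The source may hold more compounds than are shown below. What is called first, only, known or untested is meant among the compounds shown, and "the series" means these compounds.

Measured compounds in an ADME assay on MRC5 cells (Homo sapiens) for cytotoxicity, read by MTT assay; on this read-out higher numbers stand for lower toxicity in this test and lower numbers for higher toxicity in this test:
- compound 1 `CCCCC#Cc1cn([C@@H]2O[C@H](CO)[C@@H](O)[C@H]2O)c(=O)[nH]c1=O` gives 11600 nM
- compound 2 `O=c1[nH]cc(C#CC2CC2)c(=O)[nH]1` gives 101000 nM
- compound 3 `O=c1[nH]c(=O)n([C@@H]2O[C@H](CO)[C@@H](O)[C@H]2O)cc1C#CC1CC1` gives 24200 nM

Compound 2 stands highest of the three numbers in this assay; compound 3 lies nearest to it and compound 1 furthest, both gaps beyond the scatter. Compound 3 and compound 1 share a core and differ in one place: butyl in place of cyclopropyl on a triple-bonded carbon. This step, a 2.1-fold lower number from compound 3 to compound 1 (0.32 log units; beyond the scatter), is modest but beyond the scatter.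

Compound 4 `CCCCC#Cc1c[nH]c(=O)[nH]c1=O` is not yet measured in this assay. It differs from compound 2 in the same way: butyl in place of cyclopropyl on a triple-bonded carbon. The change is the same, with the same surroundings at the place. The difference between the two cores, that of compound 2 and that of compound 3, is not broken down here.

Among the measured compounds shown here, on the single precedent of compound 3 to compound 1, a 2.1-fold lower number from compound 3 to compound 1 (0.32 log units; beyond the scatter), the step from compound 2 to compound 4 is expected to be of similar size, a 2.1-fold lower number from compound 2 to compound 4 (0.32 log units; beyond the scatter), though only one pair supports this and the cores differ. For compound 4 the expected value in this assay is 48000 nM, within 20000 nM to 110000 nM.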

Compound 4, half-maximal cytotoxic concentration: 113000 nM
For compound 4 the middle estimate is 2.4-fold (0.37 log units) below the measured one, and the stated range ends below it.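

In this assay, butyl in place of cyclopropyl on a triple-bonded carbon gives a 1.1-fold higher number from compound 2 to compound 4 (0.05 log units; within the scatter), so on the core of compound 2 the change has no readable effect. Set beside the step on the other core, the two results do not differ by more than repeated measurements would allow: the same change on two cores in this assay, a 2.1-fold lower number (0.32 log units; beyond the scatter) from compound 3 to compound 1 and a 1.1-fold higher number (0.05 log units; within the scatter) from compound 2 to compound 4, 2.3-fold (0.37 log units) apart, within the scatter of two such steps. The change therefore carries across these two cores without a detectable disagreement, but two pairs do not show that it has one shared size, nor do they establish that the step is truly larger on one core than on the other.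

The compounds shown leave open how either core responds to other groups on the triple-bonded carbon, such as a longer chain, an amine or a carboxylic acid. Also open, as far as these compounds go, is whether this agreement holds on a third core or on any other read-out.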